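The source may report more compounds than this note shows. Statements on the series, on what has been measured and on what is new or still open speak of the compounds shown alone.

Compound 3 `CS(=O)(=O)Nc1cccc2c1CCC2c1ncc[nH]1` stands at a limit of a functional assay on CHO cells for agonist activity at Alpha-1B adrenergic receptor (Homo sapiens), read by FLIPR and calcium flux; on this read-out lower numbers stand for an effect already at smaller amounts and higher numbers for an effect only at larger amounts of compound: in this assay compound 3 gives > 10000 nM, a limit rather than a number. Compound 1 `Cn1ccc(-c2cccc3c2CCC3c2ncc[nH]2)n1` likewise gives a limit in this assay, > 10000 nM. Compound 2 `COc1cccc2c1CCC2c1ncc[nH]1` also gives a limit in this assay, > 10000 nM. Because all three values sit at the limit of > 10000 nM in this assay, at which 3 of the 3 values shown sit, the steps a step that the two limits leave unreadable from compound 1 to compound 2, a step that the two limits leave unreadable from compound 1 to compound 3 and a step that the two limits leave unreadable from compound 2 to compound 3 cannot be sized. Compound 4 `c1cncc(-c2cccc3c2CCC3c2ncc[nH]2)c1` differs from compound 3 by pyridin-3-yl in place of methanesulfonamido on an aromatic carbon. Compound 1 carries 1-methyl-1H-pyrazol-3-yl on an aromatic carbon and gives > 10000 nM, so an aromatic group there has not yet produced a readable value. Compound 4 is therefore expected to remain at the limit, the expected step being a step that the limit leaves unreadable from compound 3 to compound 4. Compound 4 is estimated at 15000 nM, between 3000 nM and 60000 nM.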

Compound 4, half-maximal effective concentration: > 10000 nM
Compound 4: no number, only a limit (the forecaster's own chance of this, stated with the estimate: 80%); the middle value does not contradict the limit.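

Among the compounds shown here, compound 4 also gives only a limit, so no step from compound 1, compound 2 or compound 3 to compound 4 can be read: the limit of > 10000 nM in this assay, at which 4 of the 4 values shown sit. In this assay the compounds shown leave open whether any group at this place gives a readable value.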